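The source may report more compounds than this note shows. Statements on the series, on what has been measured and on what is new or still open speak of the compounds shown alone.

Compound 3 `O=C(Nc1ccccc1)c1nc([N+](=O)[O-])c(Sc2c(Cl)cncc2Cl)s1` gives 40500 nM in an assay on isolated protein for inhibition of ubiquitin carboxyl-terminal hydrolase 7 (Homo sapiens), read by fluorescence, with stated times of 30 min and 3 h (on this read-out lower numbers stand for stronger inhibition and higher numbers for weaker inhibition), the highest of the three numbers recorded; compound 1 `CC(=O)c1nc([N+](=O)[O-])c(Sc2c(Cl)cccc2Cl)s1` gives 4490 nM and compound 2 `CC(=O)c1nc([N+](=O)[O-])c(Sc2c(Cl)cncc2Cl)s1` gives 670 nM. Compound 4 `Cc1ccc(CNC(=O)c2nc([N+](=O)[O-])c(Sc3c(Cl)cncc3Cl)s2)cc1` carries 4-methylbenzyl in place of phenyl on an amide-type nitrogen. For the measured compounds named here, the only measured step that touches the amide is a 60-fold higher number from compound 2 to compound 3 (1.78 log units; beyond the scatter), and it concerns the group on the carbonyl carbon rather than the group on the amide-type nitrogen, so no recorded step bears directly on this exchange. With compound 3 already at the weak end of the series, a modest shift in either direction is plausible, and the account leans toward a somewhat lower number. Compound 4 is therefore expected to show a 2.0-fold lower number from compound 3 to compound 4 (0.31 log units; beyond the scatter). The estimate for compound 4 is 20000 nM, spanning 5000 nM to 60000 nM.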

Compound 4, half-maximal inhibitory concentration: 3650 nM
Compound 4: middle estimate off by 5.5-fold (0.74 log units), on the high side, and the stated range ends above it.
By their numbers in this assay, from the lowest: compound 2; then compounds 4 and 1 (each within the scatter of the next); then compound 3.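

For the compounds shown here, the group on the amide-type nitrogen matters in its own right: 4-methylbenzyl in place of phenyl gives a large step (an 11-fold lower number from compound 3 to compound 4 (1.05 log units; beyond the scatter)), which the earlier compounds could not show, since their only step concerned the group on the carbonyl carbon. The amide does not fully recover the level of the methyl compound, and a modest loss remains (a 5.4-fold higher number from compound 2 to compound 4 (0.74 log units; beyond the scatter)). Nothing measured here explains either step.

The compounds shown leave open whether the gain comes from the benzyl part or from the methyl of 4-methylbenzyl, which plain benzyl on the amide-type nitrogen would separate. They also leave open whether a longer chain such as phenethyl would lower the number further.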